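A few compounds are considered here, and "the series" means these few. Any claim that something is new, unique, unknown or untested is made for them only; others in the source may bear on it.

Compound 2 `O=C1O[C@H]([C@@H](O)Cn2cc(-c3ccc(Br)cc3)nn2)C(OCc2ccccc2)=C1OCc1ccccc1` gives 5070 nM in a functional assay on HepG2 cells (Homo sapiens) for antiproliferative activity, read by MTT assay, with a stated time of 72 h; on this read-out lower numbers stand for stronger inhibition and higher numbers for weaker inhibition. Compound 3 `O=C1O[C@H]([C@@H](O)Cn2cc(-c3cccc(O)c3)nn2)C(OCc2ccccc2)=C1OCc1ccccc1` carries 3-hydroxyphenyl where compound 2 carries 4-bromophenyl; in this assay compound 3 gives 62700 nM, and that exchange reads as a 12-fold higher number from compound 2 to compound 3 (1.09 log units; beyond the scatter). Among the measured compounds shown here, compound 3 therefore stands highest of the two numbers known in this assay. Compound 1 `O=C1O/C(=C\Cn2cc(-c3ccc(Br)cc3)nn2)C(OCc2ccccc2)=C1OCc1ccccc1` reaches only a limit of this assay, > 100000 nM. Compound 4 `CCCCc1cn(C[C@H](O)[C@H]2OC(=O)C(OCc3ccccc3)=C2OCc2ccccc2)nn1` has not yet been measured in this assay. It differs from compound 3 in one place: butyl in place of 3-hydroxyphenyl on an aromatic carbon. For the measured compounds named here, only one measured step concerns the group on that aromatic carbon of the five-membered ring, and it was large, a 12-fold higher number from compound 2 to compound 3 (1.09 log units; beyond the scatter); it shows that the 3-hydroxyphenyl of compound 3 sits well beyond the 4-bromophenyl of compound 2, but it does not test a chain in place of an aryl ring. Taking the loss of the 3-hydroxyphenyl as a partial return toward compound 2, a moderately lower number is expected for compound 4, a 3.1-fold lower number from compound 3 to compound 4 (0.50 log units; beyond the scatter). Compound 4 is thus estimated at 20000 nM, with a range from 5000 nM to 90000 nM.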

Compound 4, half-maximal inhibitory concentration: 32800 nM
Beside the measured number, compound 4's estimate is 1.6-fold (0.21 log units) below it, within the range that was stated.
By their numbers in this assay, from the lowest: compound 2; then compounds 4 and 3 (each within the scatter of the next). At a limit, above all of these: compound 1.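

In this assay, replacing 3-hydroxyphenyl with butyl gives a 1.9-fold lower number from compound 3 to compound 4 (0.28 log units; within the scatter), so compound 3, with its aryl ring, and compound 4, without one, cannot be told apart at this position. An aryl ring on this aromatic carbon is therefore not enough in itself for the lower number seen with 4-bromophenyl, and butyl in place of that group gives a 6.5-fold higher number from compound 2 to compound 4 (0.81 log units; beyond the scatter), which leaves compound 2 clearly apart from the chain as well as from the 3-hydroxyphenyl compound. The data shown offer no measured explanation for this separation.

On these data alone, whether the bromine matters, or the ring that carries it, remains open, and a plain phenyl or a 4-chlorophenyl group would bear on that. As far as these compounds go, how far the chain result extends also remains open, for example to a hexyl chain or an aminobutyl group.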